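The source may hold more compounds than are shown below. What is called first, only, known or untested is meant among the compounds shown, and "the series" means these compounds.

Of the compounds shown here, three built on one shared core have been measured in an assay on CHO cells for antagonist activity at transient receptor potential cation channel subfamily V member 1 (Homo sapiens), read by FLIPR and calcium flux; on this read-out higher numbers stand for weaker inhibition and lower numbers for stronger inhibition. Compound 1 `CCCc1nc(C(F)(F)F)ccc1CNC(=O)C(C)c1ccc(NS(C)(=O)=O)c(F)c1` gives 22.7 nM. Compound 2 `CC(C(=O)NCc1ccc(C(F)(F)F)nc1CCC(C)(C)C)c1ccc(NS(C)(=O)=O)c(F)c1` gives 0.6 nM, and compound 3 `CCC1CCC(c2nc(C(F)(F)F)ccc2CNC(=O)C(C)c2ccc(NS(C)(=O)=O)c(F)c2)CC1` gives 0.3 nM. Compound 3 has the lowest number of the three. Its nearest neighbour is compound 2, with a 2.0-fold lower number from compound 2 to compound 3 (0.30 log units; within the scatter), a step within the scatter, so these two cannot be ranked against each other; the step of a 76-fold lower number from compound 1 to compound 3 (1.88 log units; beyond the scatter) lies far beyond the scatter.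

Compound 4 `CC(C(=O)NCc1ccc(C(F)(F)F)nc1C1=CCCCC1)c1ccc(NS(C)(=O)=O)c(F)c1` has not yet been measured. It differs from compound 3 in one place: cyclohex-1-en-1-yl in place of 4-ethylcyclohexyl on an aromatic carbon. The entering group has fewer heavy atoms than the one it replaces and carries one double bond outside aromatic rings.

The measured steps that bear on this change all concern the same aromatic carbon. Replacing propyl with groups of more heavy atoms gave a 38-fold lower number from compound 1 to compound 2 (1.58 log units; beyond the scatter) and a 76-fold lower number from compound 1 to compound 3 (1.88 log units; beyond the scatter), while exchanging one of those groups for the other gave only a 2.0-fold lower number from compound 2 to compound 3 (0.30 log units; within the scatter). Cyclohex-1-en-1-yl has fewer heavy atoms than 4-ethylcyclohexyl but more than propyl, so compound 4 is expected to give back part of that gain, a step of a 10-fold higher number from compound 3 to compound 4 (1.00 log units; beyond the scatter). Compound 4 is therefore estimated at 3 nM, with a range from 0.8 nM to 12 nM.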

Compound 4, inhibition constant: 0.7 nM
Beside the measured number, compound 4's estimate is 4.3-fold (0.63 log units) above it; measured number below the stated range.
By their numbers in this assay, from the lowest: compounds 3, 2 and 4 (each within the scatter of the next, the first and the last beyond it); then compound 1.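

With fewer heavy atoms than 4-ethylcyclohexyl, cyclohex-1-en-1-yl still keeps most of the gain over propyl in this assay at this aromatic carbon next to the ring nitrogen: the exchange gives a 32-fold lower number from compound 1 to compound 4 (1.51 log units; beyond the scatter) while removing the larger ring substituent costs only a 2.3-fold higher number from compound 3 to compound 4 (0.37 log units; beyond the scatter) and so is a modest step. Against the open chain of 3,3-dimethylbutyl, the same group gives a 1.2-fold higher number from compound 2 to compound 4 (0.07 log units; within the scatter) and the two cannot be ranked, which means that a ring with a double bond and a branched saturated chain serve equally well here on this read-out. For the compounds shown here, the earlier compounds showed only that two larger saturated groups far outdid propyl, whereas compound 4 shows that neither a saturated group nor the full size of 4-ethylcyclohexyl is needed for most of that gain.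

Going by these compounds, what a plain cyclohexyl, a phenyl ring or a cyclohexane carrying an amine would give at this position remains open, and so does whether the double bond matters on its own. Nothing available here gives a reason for the size of these steps.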